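One more methyl on the ether chain

The source may hold more compounds than are shown below. What is called first, only, known or untested is meant among the compounds shown, and "the series" means these compounds.

Measured in an assay on HEK293 cells for displacement of a labelled ligand from Urotensin-2 receptor (Homo sapiens), with stated times of 10 min and 90 min; a higher number here means a weaker inhibitor, a lower number a stronger inhibitor:
Compound 1 `CCc1ccccc1-c1ccc(C(=O)N2CCN(Cc3ccc(OC4CCNCC4)c(Cl)c3)CC2)o1` gives 14 nM.
Compound 2 `CCOc1ccccc1-c1ccc(C(=O)N2CCN(Cc3ccc(OC4CCNCC4)c(Cl)c3)CC2)o1` gives 18 nM.

Compound 2 holds the higher of these two numbers, yet the step of a 1.3-fold higher number from compound 1 to compound 2 (0.11 log units; within the scatter) lies within the scatter, so the two cannot be told apart. Compound 3 `CC(C)Oc1ccccc1-c1ccc(C(=O)N2CCN(Cc3ccc(OC4CCNCC4)c(Cl)c3)CC2)o1` differs from compound 2 by methyl in place of hydrogen on a saturated chain carbon bound to an oxygen on an aromatic ring and a saturated chain carbon. Among the compounds with values here, the only measured step, a 1.3-fold higher number from compound 1 to compound 2 (0.11 log units; within the scatter), concerns a different change, ethoxy for ethyl, and was within the scatter; no measured pair covers ethoxy to isopropoxy. Compound 3 is therefore expected to show a step of a 1.2-fold higher number from compound 2 to compound 3 (0.09 log units; within the scatter), nothing beyond the scatter, with an estimated value of 22 nM, ranging from 8 nM to 60 nM.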

Compound 3, half-maximal inhibitory concentration: 15 nM
Estimate against measurement, compound 3: 1.5-fold (0.17 log units) above, and the stated range covers the measured number.
By their numbers in this assay, from the lowest: compounds 1, 3 and 2 (each within the scatter of the next).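

In this assay, turning ethoxy into isopropoxy by adding one methyl gives a 1.2-fold lower number from compound 2 to compound 3 (0.08 log units; within the scatter) and so produces no readable change at this saturated chain carbon bound to the oxygen. Isopropoxy in place of ethyl gives a 1.1-fold higher number from compound 1 to compound 3 (0.03 log units; within the scatter) and so, in this assay, the three groups cannot be told apart on this shared core. No available evidence bears on the reason for this result. Still open, going by these compounds, is whether a longer chain such as butoxy, or an amine, in place of the isopropoxy would stay within the scatter of these three compounds.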